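Replacing a Cyclopentyl Amide with a Diethyl Amide

The compounds below may be only part of what the source reports. "The series", "measured", "known", "first", "only" and "open" are said of these compounds alone.

Compound 1: `CCCCNC(=O)C1CCCN(c2nc(N)c3cc(OC)c(OC)cc3n2)C1` — 8.25 nM
Compound 2: `COc1cc2nc(N3CCC(C(=O)NC4CCCC4)CC3)nc(N)c2cc1OC` — 0.63 nM

Of the compounds shown here, two sharing the same core have been measured in an assay on isolated protein for displacement of a labelled ligand from Adrenergic receptor alpha-1 (Rattus norvegicus); a higher number here means a weaker inhibitor, a lower number a stronger inhibitor. Compound 2 has the lower of the two numbers, and the number for compound 1 lies beyond the usual scatter above it. Compound 3, `CCN(CC)C(=O)C1CCN(c2nc(N)c3cc(OC)c(OC)cc3n2)CC1`, has not been measured. It differs from compound 2 in one place: diethylamino in place of cyclopentylamino on a carbonyl carbon. Among the measured compounds shown here, no measured pair shows this kind of change, so the expected step is uncertain. A moderate weakening is expected, so that compound 3 is estimated at 1.8 nM, within 0.5 nM to 8 nM, an expected step of a 2.9-fold higher number from compound 2 to compound 3 (0.46 log units; beyond the scatter).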

Compound 3, inhibition constant: 1.11 nM
Compound 3: the middle estimate sits 1.6-fold (0.21 log units) above what was measured; the measured number falls inside the stated range.
By their numbers in this assay, from the lowest: compounds 2 and 3 (each within the scatter of the next); then compound 1.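

In this assay, putting diethylamino in place of cyclopentylamino on the carbonyl carbon gives a 1.8-fold higher number from compound 2 to compound 3 (0.25 log units; within the scatter), a step within the usual scatter. This position therefore accepts the loss of both the ring and the amide hydrogen without a change that repeat measurements could distinguish. Nothing measured here explains this result. Still open, as far as these compounds go, is how ethylamino, which keeps the amide hydrogen but has no ring, would compare with these two groups. From the compounds shown here alone, a larger ring, as in cyclohexylamino, is also open.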